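Thiophene in Place of Chlorophenyl on a Shared Core

A few compounds are considered here, and "the series" means these few. Any claim that something is new, unique, unknown or untested is made for them only; others in the source may bear on it.

Compound 1 `CSc1ccc(/C=N/n2c(Cc3ccc(S(C)(=O)=O)cc3)n[nH]c2=S)cc1` gives 57.5%
Compound 2 `CS(=O)(=O)c1ccc(Cc2n[nH]c(=S)n2/N=C/c2ccc(Cl)cc2)cc1` gives 54%
Compound 3 `COc1ccc2cc(/C=N/n3c(Cc4ccc(S(C)(=O)=O)cc4)n[nH]c3=S)ccc2c1` gives 54.1%

In a functional assay on HeLa cells (Homo sapiens) for cytotoxicity, read by MTT assay, with a stated time of 48 h, tested at 50 uM (on this read-out lower numbers stand for a weaker effect and higher numbers for a stronger effect at the one concentration tested), compound 1 gives 57.5%, compound 2 gives 54% and compound 3 gives 54.1%. Compound 2 has the lowest number of the three, but its gaps to compound 3 and to compound 1 both lie within the scatter, so the three cannot be ordered.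

Compound 4 `CS(=O)(=O)c1ccc(Cc2n[nH]c(=S)n2/N=C/c2cccs2)cc1` differs from compound 2 in one place: thiophen-2-yl in place of 4-chlorophenyl on a carbon with a double bond to nitrogen

Going by the values given here, the one measured step that touches the same part of the shared core is a number 3.5 percentage points lower from compound 1 to compound 2 (within the scatter), and it lay within the scatter. Among the compounds with values here, it swaps a group on the six-membered ring rather than the ring itself, so it bears only loosely on the present change; no measured step exchanges the aryl ring for a five-membered heteroaryl. Because a number 3.5 percentage points lower from compound 1 to compound 2 (within the scatter) stayed within the scatter, the expected step of a number 1 percentage points lower from compound 2 to compound 4 (within the scatter) is no more than the scatter. Compound 4 is therefore estimated at 53%, with a range from 43% to 63%.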

Compound 4, a percentage reported as activity, at one concentration (the size of the read-out at that concentration, not a potency): 48.6%
For compound 4 the middle estimate is 4.4 percentage points above the measured one, and the stated range covers the measured number.
By their numbers in this assay, from the lowest: compounds 4, 2, 3 and 1 (each within the scatter of the next).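

In this assay, going by these compounds alone, the first exchange of the whole aryl ring at this position, thiophen-2-yl in place of 4-chlorophenyl, gives a number 5.4 percentage points lower from compound 2 to compound 4 (within the scatter), and the same comparison with the 4-(methylsulfanyl)phenyl group gives a number 8.9 percentage points lower from compound 1 to compound 4 (within the scatter). Both steps stay within the scatter, so on a carbon with a double bond to nitrogen this read-out does not separate a five-membered aromatic ring with 1 hetero atom from either of these six-membered rings. No measurement bearing on the origin of these steps is available.

The compounds shown leave open whether furan-2-yl, pyridin-3-yl, or a phenyl ring carrying an amine or a carboxylic acid would give a step beyond the scatter at this position. With readings at a single concentration, they also leave the potency of all four compounds open.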